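The source may report more compounds than this note shows. Statements on the series, on what has been measured and on what is new or still open speak of the compounds shown alone.

Measured compounds and their numbers in a functional assay on UO-31 cells (Homo sapiens) for cytotoxicity, read by sulforhodamine B assay, with a stated time of 48 h, tested at 0.001 uM; on this read-out higher numbers stand for a weaker effect at the one concentration tested and lower numbers for a stronger effect:

- compound 1 `COc1cc(C)cc(-c2c(-c3ccnc(-c4ccc(N(C)C)cc4)c3)cnn2CC#N)c1`, which gives 83%
- compound 2 `COc1cc(C)cc(-c2nn(CC#N)cc2-c2ccnc(-c3ccc(N(C)C)cc3)c2)c1`, which gives 90%
- compound 3 `COc1cc(C)cc(-c2nn(CC#N)cc2-c2ccc(-c3cccc(C(C)=O)c3)nc2)c1`, which gives 86%

All three compounds share the same core and were tested at a single, very low concentration, so the read-out tells the size of the effect at that concentration, not how strong or weak each compound would be over a range of concentrations. Compound 2 gives the highest of the three numbers, but compound 3 sits only a few points lower and compound 1 a few more, and both gaps lie within the usual scatter of this measurement. On these numbers, then, nothing separates the three compounds from one another; each shows at best a weak effect at this concentration.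

Compound 4 `Cc1cc(O)cc(-c2nn(CC#N)cc2-c2ccnc(-c3ccc(N(C)C)cc3)c2)c1` has not yet been measured. It differs from compound 2 in one place:

hydrogen in place of methyl on an oxygen on an aromatic ring

For the measured compounds named here, no pair of measured compounds shows this change, so no measured step guides the expectation directly. Given that the three measured compounds all cluster at a weak effect, a change this small is expected to leave the read-out about where it is, with no step beyond the scatter in either direction: a number 2 percentage points lower from compound 2 to compound 4 (within the scatter). Compound 4 is therefore expected to give about 88%, somewhere between 78% and 98%.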

Compound 4, a percentage reported as activity, at one concentration (the size of the read-out at that concentration, not a potency): 89%
The estimate for compound 4 lay 1 percentage points below the measured number, within the range that was stated.
By their numbers in this assay, from the lowest: compounds 1, 3, 4 and 2 (each within the scatter of the next).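

In this assay, for the compounds shown here, the change from methoxy to hydroxy on the 3-methoxy-5-methylphenyl group gives a number 1 percentage points lower from compound 2 to compound 4 (within the scatter), the only comparison so far between two compounds that differ in one place. Going by these compounds alone, it shows that, at this single very low concentration, the read-out does not separate the methyl on this oxygen from a hydrogen, something the earlier compounds could not show because they differ from each other in more than one place. Since both compounds show at best a weak effect here, this is a narrow finding about one concentration, and nothing available offers an explanation for it.

On these data alone, what a longer chain on this oxygen, such as ethyl or propyl, or an amine in place of the hydroxy would do to the read-out remains open. Also open, as far as these compounds go, is whether compound 2 and compound 4 would remain indistinguishable at concentrations where the effect is larger, as a single concentration cannot show how either compound behaves across a range.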